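Compound 2 to compound 4: cycloheptyl on the carbonyl carbon

The source may hold more compounds than are shown below. What is called first, only, known or untested is meant among the compounds shown, and "the series" means these compounds.

In an ADME assay on MT4 cells (Homo sapiens) for cytotoxicity, with a stated time of 5 days (on this read-out lower numbers stand for higher toxicity in this test and higher numbers for lower toxicity in this test), compound 2 `CC(C)N(c1cc(C#CC(C)(C)C)sc1C(=O)O)C(=O)[C@H]1CC[C@H](CF)CC1` gives > 20000 nM, which is a limit of the assay and not a number. Compound 1 `CC(C)(C)C#Cc1cc(N(C(=O)[C@H]2CC[C@H](C)CC2)[C@H]2CC[C@H](OC3CCOC3)CC2)c(C(=O)O)s1` gives > 20000 nM, also a limit. Compound 3 `CON=C1CCC(N(c2cc(C#CC(C)(C)C)sc2C(=O)O)C(=O)[C@H]2CC[C@H](C)CC2)CC1` gives > 20000 nM, again a limit. The whole measured set therefore comes down to the limit of > 20000 nM in this assay, at which 3 of the 3 values shown sit. Among the measured compounds shown here, the one measured step is a step that the two limits leave unreadable from compound 1 to compound 3, so it offers no size to carry over.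

Compound 4 `CC(C)N(C(=O)C1CCCCCC1)c1cc(C#CC(C)(C)C)sc1C(=O)O` departs from compound 2 in one place: cycloheptyl in place of 4-(fluoromethyl)cyclohexyl on a carbonyl carbon. In short, cycloheptyl stands in place of 4-(fluoromethyl)cyclohexyl on a carbonyl carbon. For the measured compounds named here, no measured step covers this change. Large changes on the amide-type nitrogen in compound 1 and compound 3 leave both at the limit, though this says nothing directly about the carbonyl side.

No step beyond the scatter is expected in this assay, and the estimated step that the limit leaves unreadable from compound 2 to compound 4 rests on (the limit of > 20000 nM in this assay, at which 3 of the 3 values shown sit). Compound 4 is expected at 22000 nM, with an estimated range of 12000 nM to 40000 nM, and will most likely be reported as a limit again.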

Compound 4, half-maximal cytotoxic concentration: > 20000 nM
Compound 4 gave a limit, no number; the forecaster's own chance of this, stated with the estimate: 80%; the middle value lies beyond the limit too.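

No step can be read from compound 2 to compound 4 in this assay, since both results are limits and not numbers: the limit of > 20000 nM in this assay, at which 4 of the 4 values shown sit.

The compounds shown leave open whether any change on the carbonyl carbon or the amide-type nitrogen moves this read-out at all, and by how much.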